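Shifting the methoxy group in compound 4

The source may hold more compounds than are shown below. What is called first, only, known or untested is meant among the compounds shown, and "the series" means these compounds.

In an ADME assay on microsomes from liver (Homo sapiens) for metabolic stability, read by LC-MS, using NADPH, with stated times of 5 min and 30 min, tested at 1 uM (on this read-out lower numbers stand for a less stable compound and higher numbers for a more stable compound), compound 3 `COc1ccc(CC[C@H](O)C[C@@H](O)c2cc(-c3ccccc3)on2)cc1` gives 32%, the lower of the two exact numbers available. Among the measured compounds shown here, the only other exact number belongs to compound 2 `O[C@@H](CCc1ccc(F)cc1)C[C@@H](O)c1cc(-c2ccccc2)on1`, at 73%, which is clearly higher. Compound 1 `COc1ccc(CC[C@H](O)C[C@H](O)c2cc(-c3ccc(OC)cc3)on2)cc1` reads < 20%, which is a limit and not a number.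

Compound 4 `COc1cccc(CC[C@H](O)C[C@@H](O)c2cc(-c3ccccc3)on2)c1` has the same atoms as compound 3, joined differently: 3-methoxyphenyl in place of 4-methoxyphenyl on a saturated chain carbon, three bonds along the chain from an oxygen on a saturated carbon. Here 3-methoxyphenyl stands in place of 4-methoxyphenyl on a saturated chain carbon, three bonds along the chain from an oxygen on a saturated carbon.

For the measured compounds named here, only one measured step bears on this change, methoxy in place of fluoro on an aromatic carbon: a number 41 percentage points lower from compound 2 to compound 3 (beyond the scatter). This large step exchanges one group for another, whereas the new change keeps the methoxy group and alters only its place. Going by the values given here, no measured pair tests such a shift, so the expectation remains uncertain. Compound 4 still carries the methoxy group, so a repeat of a step as large as a number 41 percentage points lower from compound 2 to compound 3 (beyond the scatter) is not expected, and no step beyond the scatter is foreseen in this assay. The expected step is a number 2 percentage points lower from compound 3 to compound 4 (within the scatter). For compound 4 the estimate is 30%, with an expected range of 15% to 50%.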

Compound 4, percent of the compound remaining: < 20%
Compound 4: a limit, no number (the forecaster's own chance of this, stated with the estimate: 20%); middle value at least 10 percentage points from the limit.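

In this assay, compound 4 sits at a limit and not at a number: the limit of < 20% in this assay, at which 2 of the 4 values shown sit.

Even so, the change can be read as a step, a number at least 12 percentage points lower from compound 3 to compound 4 (beyond the scatter), so the earlier compounds' lesson is sharpened: with the same atoms present, exchanging 4-methoxyphenyl for 3-methoxyphenyl on this saturated chain carbon is enough to move the read-out beyond the scatter. Set against the fluorinated compound, the same position gives a number at least 53 percentage points lower from compound 2 to compound 4 (beyond the scatter), which places 3-methoxyphenyl, like 4-methoxyphenyl before it, clearly on the less stable side of 4-fluorophenyl.

The compounds shown leave open how far under the limit compound 4 really lies, and whether 3-fluorophenyl would show a similar loss, which would separate the effect of the group's place from that of the methoxy group itself. They also leave open how this position would read with a chloro group on the ring, with an ethoxy group in place of methoxy, or with a longer chain between the ring and the oxygen-bearing carbon.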